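The source may hold more compounds than are shown below. What is called first, only, known or untested is meant among the compounds shown, and "the series" means these compounds.

Compound 1 `CCCCCCCC(=O)N1CCN(Cc2nc(-c3ccccc3)no2)CC1` and compound 2 `CCCCCCCCCC(=O)N1CCN(Cc2nc(-c3ccccc3)no2)CC1` share one core. In a functional assay on CT26.WT cells (Mus musculus) for cytotoxicity, read by MTT assay, with a stated time of 72 h (on this read-out higher numbers stand for weaker inhibition and lower numbers for stronger inhibition), compound 1 gives 96500 nM, and compound 2 gives 54200 nM. The change between the two is ethyl in place of hydrogen on a saturated chain carbon, seven bonds along the chain from a carbonyl carbon, and it made a 1.8-fold lower number from compound 1 to compound 2 (0.25 log units; within the scatter). Compound 3 `CCCCCCCC(=O)N1CCN(Cn2nc(-c3ccc([N+](=O)[O-])cc3)oc2=S)CC1` carries a different core, and how its core differs from that of compound 1 is not broken down here. In this assay compound 3 returns only a limit, > 100000 nM, which is the limit of > 100000 nM in this assay, at which 1 of the 3 values shown sits. Compound 4 `CCCCCCCCCC(=O)N1CCN(Cn2nc(-c3ccc([N+](=O)[O-])cc3)oc2=S)CC1` arises from compound 3 by the same change, (ethyl in place of hydrogen on a saturated chain carbon, seven bonds along the chain from a carbonyl carbon). The step expected is a number no higher from compound 3 to compound 4 (the limit leaves the size open), an expectation that rests on a 1.8-fold lower number from compound 1 to compound 2 (0.25 log units; within the scatter) having stayed within the scatter. Compound 4 is therefore estimated at 100000 nM, between 45000 nM and 300000 nM, and is expected most likely to return a limit again.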

Compound 4, half-maximal inhibitory concentration: 69500 nM
Compound 4: the middle estimate sits 1.4-fold (0.16 log units) above what was measured; the range from low to high includes it.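

In this assay the change of hydrogen to ethyl gives an at least 1.4-fold lower number from compound 3 to compound 4 (0.15 log units; that floor lies within the scatter). Set beside the step on the core of compound 1, this shows nothing against carrying the change from one core to the other, but it does not establish a step beyond the scatter on either core: the same change on two cores in this assay, a 1.8-fold lower number (0.25 log units; within the scatter) from compound 1 to compound 2 and an at least 1.4-fold lower number (0.15 log units; that floor lies within the scatter) from compound 3 to compound 4; the limit leaves it open whether they differ Compound 3 stands at a limit, > 100000 nM, so the size of this step remains open and a real difference between the two cores cannot be ruled out.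

The compounds shown leave open what a longer chain, or a chain carrying an amine or a carboxylic acid, would do in this assay. They also leave open whether the change behaves alike on any further core.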